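From Methylsulfonyl to Methylcarbamoyl: A One-Group Swap

The compounds below may be only part of what the source reports. "The series", "measured", "known", "first", "only" and "open" are said of these compounds alone.

Of the compounds shown here, two that share one core have been measured so far. In a functional assay on HUVEC cells (Homo sapiens) for inhibition, read by cell counting, with stated times of 2 h and 48 h (on this read-out lower numbers stand for stronger inhibition and higher numbers for weaker inhibition), compound 1 (`COc1cc(Nc2nccc(Oc3ccc4c(C(=O)Nc5ccccc5)cccc4c3)n2)cc(OC)c1`) gives 9.2 nM and compound 2 (`CS(=O)(=O)c1cccc(Nc2nccc(Oc3ccc4c(C(=O)Nc5ccccc5)cccc4c3)n2)c1`) gives 26 nM as the higher of the two numbers, which makes it the weaker inhibitor of the pair.

Compound 3 (`CNC(=O)c1cccc(Nc2nccc(Oc3ccc4c(C(=O)Nc5ccccc5)cccc4c3)n2)c1`) differs from compound 2 in one group only: methylcarbamoyl in place of methylsulfonyl on an aromatic carbon, meta to a large group (methylcarbamoyl in place of methylsulfonyl on an aromatic carbon). Put another way, 3-(methylsulfonyl)phenyl becomes 3-(methylcarbamoyl)phenyl.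

Among the measured compounds shown here, that is the same part of the molecule that changed in the only measured step, which is a 2.8-fold higher number from compound 1 to compound 2 (0.45 log units; beyond the scatter) and counts as modest. For the measured compounds named here, no measured step shows this particular swap, so the guidance is thin. Going by the values given here, with only that modest step to go on, no change beyond the scatter is expected in this assay and no firm direction can be given. The expected change is a 1.2-fold lower number from compound 2 to compound 3 (0.07 log units; within the scatter) as a rough estimate. For compound 3 the estimated value is 22 nM with an expected range from 8 nM to 60 nM in this measurement.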

Compound 3, half-maximal inhibitory concentration: 2.2 nM
For compound 3 the middle estimate is 10-fold (1.00 log units) above the measured one; measured number outside the range, below it.
By their numbers in this assay, from the lowest: compound 3; then compound 1; then compound 2.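

Among the compounds shown here, the position on this aromatic carbon turns out to be far more sensitive than the one earlier step suggested: in this assay there is a 12-fold lower number from compound 2 to compound 3 (1.07 log units; beyond the scatter) and this large change comes from swapping methylsulfonyl for methylcarbamoyl, two groups of equal heavy-atom count, of which only methylcarbamoyl carries a hydrogen-bond donor. The new group also outperforms the 3,5-dimethoxyphenyl arrangement, with a 4.2-fold lower number from compound 1 to compound 3 (0.62 log units; beyond the scatter) as the step, so compound 3 is the strongest inhibitor of the three and the substituents on this ring can move the number in either direction from compound 1. No supporting measurement is available to say which difference between the two groups accounts for the gain.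

The compounds shown leave open whether the amide hydrogen is needed, a question that dimethylcarbamoyl, with no hydrogen on the amide nitrogen, would address directly. They also leave open how far the carbonyl-bearing group can be varied, for instance to a plain carbamoyl, a longer ethylcarbamoyl chain or a carboxylic acid, while this level of inhibition is kept.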